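Dropping one chloro from the hydrazone aryl ring

The source may hold more compounds than are shown below. What is called first, only, known or untested is meant among the compounds shown, and "the series" means these compounds.

Of the compounds shown here, three sharing one core have been measured in a functional assay on HepG2 cells (Homo sapiens) for inhibition, read by MTT assay, with a stated time of 72 h; on this read-out higher numbers stand for weaker inhibition and lower numbers for stronger inhibition. Compound 1 `Cc1nc(N(C)C(=O)NC(=O)c2c(F)cccc2F)sc1C(=O)N/N=C/c1ccc(C(F)(F)F)cc1` carries a 4-(trifluoromethyl)phenyl group on the carbon with a double bond to nitrogen; in this assay compound 1 reaches only the limit > 100 ug/mL, which is a boundary of the measurement and not a number. Compound 2 `COc1ccc(/C=N/NC(=O)c2sc(N(C)C(=O)NC(=O)c3c(F)cccc3F)nc2C)cc1`, with a 4-methoxyphenyl group in that place, gives 22.7 ug/mL. Compound 3 `Cc1nc(N(C)C(=O)NC(=O)c2c(F)cccc2F)sc1C(=O)N/N=C/c1ccc(Cl)cc1Cl`, with a 2,4-dichlorophenyl group, gives 70 ug/mL, which is the higher of the two numbers: the step of a 3.1-fold higher number from compound 2 to compound 3 (0.49 log units; beyond the scatter). The step of an at least 4.4-fold lower number from compound 1 to compound 2 (0.64 log units; beyond the scatter) and the step of an at least 1.4-fold lower number from compound 1 to compound 3 (0.15 log units; that floor lies within the scatter) are read against a limit (the limit of > 100 ug/mL in this assay, at which 1 of the 3 values shown sits).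

Compound 4 `Cc1nc(N(C)C(=O)NC(=O)c2c(F)cccc2F)sc1C(=O)N/N=C/c1ccc(Cl)cc1` differs from compound 3 by one change: hydrogen in place of chloro on an aromatic carbon. Among the measured compounds shown here, no measured step removes a chloro group; all three steps swap one whole aryl pattern for another, and those swaps move the number only modestly or not at all. A comparably small step is therefore expected here, in either direction, so the step of a 1.3-fold lower number from compound 3 to compound 4 (0.10 log units; within the scatter) is estimated as one within or just beyond the scatter. Compound 4 is expected to give 55 ug/mL in this assay, most likely between 20 ug/mL and 100 ug/mL.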

Compound 4, half-maximal inhibitory concentration: > 100 ug/mL
Compound 4: no number, only a limit (the forecaster's own chance of this, stated with the estimate: 25%); middle value at least 1.8-fold (0.25 log units) from the limit.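

In this assay, compound 4 reaches only > 100 ug/mL, which is a limit and not a number. Removing the chloro that sits ortho to a large group gives an at least 1.4-fold higher number from compound 3 to compound 4 (0.15 log units; that floor lies within the scatter), so this change brings no measurable gain in inhibition, though the data cannot show a real loss either, while comparing the single para-free pattern is unnecessary: the sharper contrast is an at least 4.4-fold higher number from compound 2 to compound 4 (0.64 log units; beyond the scatter), which shows that the 4-methoxyphenyl compound keeps a clear edge over the 4-chlorophenyl compound. The step between compound 1 and compound 4 cannot be read, because both rest on the same boundary: the limit of > 100 ug/mL in this assay, at which 2 of the 4 values shown sit.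

From the compounds shown here alone, how far compound 4 lies beyond its limit remains unknown, so the true size of the effect of losing this chloro stays open. It is also open whether a hydroxyl group or a dimethylamino group on the aryl ring, in place of the methoxy of compound 2, would give a lower number than the methoxy does, or whether the methoxy result stands alone among these compounds.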